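A few compounds are considered here, and "the series" means these few. Any claim that something is new, unique, unknown or untested is made for them only; others in the source may bear on it.

Measured so far:
compound 1 `N#CC(C#N)C(c1ccccc1)c1c(-c2ccccc2)[nH]c2ccccc12`: 0.247 h
compound 2 `O=C(C(c1ccccc1)c1c(-c2ccccc2)[nH]c2ccccc12)C(F)(F)F`: 0.69 h

In an ADME assay on microsomes from liver (Rattus norvegicus) for metabolic stability, read by LC-MS, using NADPH, tested at 3 uM (on this read-out higher numbers stand for a longer-lived compound and lower numbers for a shorter-lived compound), compound 2 gives 0.69 h and holds the higher of the two numbers. Compound 3 `OC(C(c1ccccc1)c1c(-c2ccccc2)[nH]c2ccccc12)C(F)(F)F` has not been measured. It carries 2,2,2-trifluoro-1-hydroxyethyl in place of (trifluoromethyl)carbonyl on a saturated chain carbon bound to two aromatic carbons. Within the data shown here, the only measured step, a 2.8-fold higher number from compound 1 to compound 2 (0.45 log units; beyond the scatter), is modest and swaps a different pair of groups on that carbon, so it offers weak guidance. In this assay the expected result is a 1.2-fold lower number from compound 2 to compound 3 (0.06 log units; within the scatter), with no step beyond the scatter anticipated. For compound 3 the estimate is 0.6 h, with an expected range from 0.25 h to 1.4 h as the likely span.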

Compound 3, half-life: 0.303 h
Compound 3: the middle estimate sits 2.0-fold (0.30 log units) above what was measured, and the stated range covers the measured number.
By their numbers in this assay, from the lowest: compounds 1 and 3 (each within the scatter of the next); then compound 2.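

In this assay, the saturated chain carbon bound to two aromatic carbons responds to a small edit: 2,2,2-trifluoro-1-hydroxyethyl in place of (trifluoromethyl)carbonyl gives a change beyond the scatter (a 2.3-fold lower number from compound 2 to compound 3 (0.36 log units; beyond the scatter)). Compared with dicyanomethyl, the same group gives no change beyond the scatter (a 1.2-fold higher number from compound 1 to compound 3 (0.09 log units; within the scatter)), so among these three only (trifluoromethyl)carbonyl stands apart. Nothing measured here accounts for this difference.

Still open, from the compounds shown here alone, is how an amine or a carboxylic acid on that carbon would compare. A methyl ether in place of the hydroxyl is equally untested by the compounds shown.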